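The compounds below may be only part of what the source reports. "The series", "measured", "known", "first", "only" and "open" are said of these compounds alone.

Measured so far in an assay on isolated protein for binding affinity to Alpha-1A adrenergic receptor (Rattus norvegicus), read by radioligand binding; a higher number here means a weaker inhibitor, a lower number a stronger inhibitor:
compound 1 `O=S(=O)(Nc1cccc2c1CCCC2c1c[nH]cn1)C1CC1` gives 537 nM;
compound 2 `CC(=O)Nc1cccc2c1CCCC2c1c[nH]cn1` gives 525 nM;
compound 3 `CCS(=O)(=O)Nc1cc(F)cc2c1CCCC2c1c[nH]cn1` gives 83.2 nM.

Compound 3 stands lowest of the three numbers; compound 2 and compound 1 both sit beyond the scatter above it. Within the data shown here, the only measured single-point step, a 1.0-fold lower number from compound 1 to compound 2 (0.01 log units; within the scatter), concerns the group on the ring nitrogen and does not touch the ring substituent, so it offers no guide here. Compound 4 `CCS(=O)(=O)Nc1cc(Cl)cc2c1CCCC2c1c[nH]cn1` differs from compound 3 by chloro in place of fluoro on an aromatic carbon. Among the measured compounds shown here, no step in this set bears on that exchange; on prior likelihood the change is expected to stay within the scatter. The step from compound 3 to compound 4 is therefore estimated at a 1.2-fold lower number from compound 3 to compound 4 (0.08 log units; within the scatter). Compound 4 is expected at 70 nM, within 25 nM to 220 nM.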

Compound 4, inhibition constant: 45.7 nM
Compound 4: the middle estimate sits 1.5-fold (0.19 log units) above what was measured; measured number inside the range.
By their numbers in this assay, from the lowest: compounds 4 and 3 (each within the scatter of the next); then compounds 2 and 1 (each within the scatter of the next).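

In this assay, chloro in place of fluoro on this aromatic carbon, meta to the (ethylsulfonyl)amino group, gives a 1.8-fold lower number from compound 3 to compound 4 (0.26 log units; within the scatter) and so stays within the scatter. At this position, the two halogens cannot be told apart, and the first exchange read here leaves the number essentially unmoved. No measured evidence accounts for this step.

Still open, on these data alone, is how a hydrogen, a methoxy or an amine on this carbon would read with the (ethylsulfonyl)amino group held fixed. Also open, as far as these compounds go, is whether chloro reads the same alongside the cyclopropylsulfonyl or acetyl group on the nitrogen.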